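Shortening the alkyl chain on the shared core

The source may hold more compounds than are shown below. What is called first, only, known or untested is meant among the compounds shown, and "the series" means these compounds.

Of the compounds shown here, three with a shared core have been measured in a functional assay (spleen, spleen) for activation, with Mus musculus as the target; on this read-out lower numbers stand for an effect already at smaller amounts and higher numbers for an effect only at larger amounts of compound. Compound 1 `Nc1ncnc2c1nc(O)n2Cc1ccc(Cl)cc1` gives 10 uM in this assay. Compound 2 `CCCCOc1nc(N)c2[nH]c(=O)n(Cc3ccccc3)c2n1` gives 0.001 uM. Compound 3 `CCc1nc(N)c2nc(O)n(Cc3ccccc3)c2n1` gives 1 uM, which places it second highest of the three numbers: compound 1 sits higher and compound 2 lower, both gaps beyond the usual scatter.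

Compound 4 `Cc1nc(N)c2nc(O)n(Cc3ccccc3)c2n1` has not yet been measured in this assay. It differs from compound 3 in one place: hydrogen in place of methyl on a saturated chain carbon bound to an aromatic carbon. Cut one bond further out, the same difference reads ethyl to methyl, so the change is a small shortening of a chain.

Among the measured compounds, compound 1 carries only hydrogen at the position where compound 3 carries its ethyl group, and compound 1 gives 10 uM, while compound 2 with its longer butoxy group gives 0.001 uM. Given these numbers, the step from compound 3 to compound 4 is expected to be a modest rise in this assay, around a 3.0-fold higher number from compound 3 to compound 4 (0.48 log units; beyond the scatter). Compound 4 is therefore estimated at 3 uM, with a likely range from 1 uM to 10 uM.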

Compound 4, minimum effective concentration: 1 uM
Compound 4: middle estimate off by 3.0-fold (0.48 log units), on the high side; the range from low to high includes it.
By their numbers in this assay, from the lowest: compound 2; then compounds 3 and 4 (each within the scatter of the next); then compound 1.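

In this assay the shortening of the chain shows no change at the digits printed from compound 3 to compound 4 (within the scatter) and so, at this place on a saturated chain carbon bound to an aromatic carbon, ethyl and methyl cannot be told apart by this read-out. Going by these compounds alone, this is the first pair that differs in one place only, which gives the first direct reading of this position; the earlier compounds differ from one another in more than one place, so their numbers could not separate the effect of this chain from that of their other differences. The result therefore shows that this particular change can be made without a visible cost or gain in the whole-organism read-out, although no measurement at hand accounts for that.

What the compounds shown leave open is how far this tolerance reaches: a propyl chain, a branched isopropyl group or a cyclopropyl ring at the same place could behave like ethyl and methyl or could move the number well beyond the scatter. An amine or a carboxylic acid on the chain would test the position with a quite different kind of group.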